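The source may hold more compounds than are shown below. What is called first, only, known or untested is meant among the compounds shown, and "the series" means these compounds.

Notes on the series.

Compound 1 `COc1cnc(-c2ccncc2)c2[nH]cc(C(=O)C(=O)N3CCN(C(=O)c4ccccc4)CC3)c12` gives 6000 nM in a functional assay on MT2 cells (Homo sapiens) for cytotoxicity, read by XTT assay, with a stated time of 3 days; on this read-out lower numbers stand for higher toxicity in this test and higher numbers for lower toxicity in this test. Among the measured compounds shown here, compound 2 `COc1cnc(-n2cc(C)cn2)c2[nH]cc(C(=O)C(=O)N3CCN(C(=O)c4ccccc4)CC3)c12` gives 243000 nM in this assay; this is the highest of the two numbers measured so far, and the step of a 41-fold higher number from compound 1 to compound 2 (1.61 log units; beyond the scatter) is the only measured change.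

Compound 3 `COc1cnc(-n2cnc(N3CCN(C)CC3)n2)c2[nH]cc(C(=O)C(=O)N3CCN(C(=O)c4ccccc4)CC3)c12` is not yet measured. Its difference from compound 2 is 3-(4-methylpiperazin-1-yl)-1H-1,2,4-triazol-1-yl in place of 4-methyl-1H-pyrazol-1-yl on an aromatic carbon.

For the measured compounds named here, only the step from compound 1 to compound 2 touches the same position of the shared core, and it did so with a different pair of groups. Going by the values given here, that step, a 41-fold higher number from compound 1 to compound 2 (1.61 log units; beyond the scatter), shows that exchanging the group at this position can move the number in this assay by a large amount, but no measured step covers a five-membered ring with three hetero atoms or a methylpiperazinyl substituent, so the direction for compound 3 is not given by the data. The working expectation for compound 3 is a number close to that of compound 2, with a step of a 1.0-fold higher number from compound 2 to compound 3 (0.01 log units; within the scatter) expected to stay within the scatter. The estimate for compound 3 in this assay is 250000 nM, within 80000 nM to 800000 nM.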

Compound 3, half-maximal cytotoxic concentration: > 300000 nM
Compound 3 was reported as a limit; the forecaster's own chance of this, stated with the estimate: 30%; middle value at least 1.2-fold (0.07 log units) away from the limit.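

Compound 3 stands in this assay as a limit of the assay and not as a number: the limit of > 300000 nM in this assay, at which 1 of the 3 values shown sits. From the compounds shown here alone, putting 3-(4-methylpiperazin-1-yl)-1H-1,2,4-triazol-1-yl in place of 4-methyl-1H-pyrazol-1-yl gives an at least 1.2-fold higher number from compound 2 to compound 3 (0.09 log units; that floor lies within the scatter), so this exchange shows no change beyond the scatter, and the true size of the step stays unknown. Measured against pyridin-4-yl, the same position gives an at least 50-fold higher number from compound 1 to compound 3 (1.69 log units; beyond the scatter), so a second group built on a five-membered aromatic ring, this one also carrying a six-membered non-aromatic ring, now stands clear of compound 1 in the same direction as compound 2.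

The compounds shown leave open whether the high numbers follow the five-membered aromatic ring itself or other parts of the entering groups. A plain 1H-1,2,4-triazol-1-yl group, or a five-membered ring carrying a simple amine or a carboxylic acid, is not among them, so the share of the 4-methylpiperazin-1-yl part in the result for compound 3 cannot be read.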